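Trimming the Ether Chain Back to Methoxy

The compounds below may be only part of what the source reports. "The series", "measured", "known", "first", "only" and "open" are said of these compounds alone.

In a functional assay on A549 cells (Homo sapiens) for inhibition, read by colorimetric assay and MTT assay, with a stated time of 72 h (a higher number here means a weaker inhibitor, a lower number a stronger inhibitor), compound 1 (`CCCCOc1ncc(-c2ccccc2OC)n1C`) gives 87000 nM. Within the data shown here, compound 2 (`C#CCCCCOc1ncc(-c2ccccc2OC)n1C`) gives 22000 nM, the lower of the two numbers measured so far. Among the measured compounds shown here, the only measured step is a 4.0-fold lower number from compound 1 to compound 2 (0.60 log units; beyond the scatter), a modest change that lies beyond the scatter and comes with ethynyl in place of hydrogen on the chain.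

Compound 3 (`COc1ccccc1-c1cnc(OC)n1C`) removes most of that chain: hydrogen in place of pent-4-yn-1-yl on a saturated chain carbon bound to an oxygen on an aromatic ring. In words, this is hydrogen in place of pent-4-yn-1-yl on a saturated chain carbon bound to an oxygen on an aromatic ring, which leaves methoxy in place of (hex-5-yn-1-yl)oxy. For the measured compounds named here, no measured step covers so large a cut, and the effect of shortening the chain alone is unknown. The best guide is a 4.0-fold lower number from compound 1 to compound 2 (0.60 log units; beyond the scatter), since compound 3 also lacks the ethynyl. A move to a higher number, of about that modest size, is therefore expected. The expected change is a 4.1-fold higher number from compound 2 to compound 3 (0.61 log units; beyond the scatter). In this assay, compound 3 is estimated at 90000 nM, with an expected range of 35000 nM to 250000 nM.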

Compound 3, half-maximal inhibitory concentration: > 100000 nM
Compound 3: only a limit was reported (the forecaster's own chance of this, stated with the estimate: 25%); at least 1.1-fold (0.04 log units) between middle value and limit.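

In this assay compound 3 gives > 100000 nM, which is a limit of the assay and not a number, so the position can be read only up to that point: the limit of > 100000 nM in this assay, at which 1 of the 3 values shown sits.

Even so, the cut has a clear direction, with an at least 4.5-fold higher number from compound 2 to compound 3 (0.65 log units; beyond the scatter): the lower number of compound 2 does not survive the loss of pent-4-yn-1-yl, which shows that the core with a bare methoxy does not hold it alone. The comparison with the saturated chain is less informative, with an at least 1.1-fold higher number from compound 1 to compound 3 (0.06 log units; that floor lies within the scatter); that floor lies within the scatter, so no order can be given between compound 1 and compound 3.

Going by these compounds, how far the number of compound 3 actually lies beyond its limit stays open, and so does whether the chain's length or its ethynyl carries the difference from compound 2. A plain hexyl chain would separate those two, while a chain ending in an amine or a carboxylic acid would show whether the ethynyl can be replaced at all.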